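Adding a methyl to the pyridine of compound 3

The compounds below may be only part of what the source reports. "The series", "measured", "known", "first", "only" and "open" are said of these compounds alone.

Compounds measured so far, all in a functional assay on the whole organism (strain Sprague-Dawley) for inhibition, with Rattus norvegicus as the target, read by paw edema, with a stated time of 180 min, at a dose of 20 mg/kg by the oral route; a lower number here means a weaker effect, a higher number a stronger effect of the compound at the dose given:
- Compound 1, `COc1ccnc(CNc2ccc3c(c2)nc(C)n3C[C@@H](O)[C@H]2O[C@H](O)[C@@H](O)[C@H]2O)c1OC`: 62%
- Compound 2, `COc1ccnc(CNc2ccc3c(c2)nc(C)n3C[C@@H](O)[C@H]2O[C@H](O)[C@@H](O)[C@H]2O)c1C`: 53%
- Compound 3, `COc1ccnc(CNc2ccc3[nH]c(C)nc3c2)c1C`: 52%

Compound 3 gives the lowest of the three numbers, but the gap to compound 2 and the gap to compound 1 both lie within the scatter, so the three compounds cannot be told apart on these numbers. For the measured compounds named here, the only single-point step measured is a number 9 percentage points lower from compound 1 to compound 2 (within the scatter), a change on the same pyridine ring as the one studied here, and it too stays within the scatter.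

Compound 4, `COc1c(C)cnc(CNc2ccc3[nH]c(C)nc3c2)c1C`, differs from compound 3 by methyl in place of hydrogen on an aromatic carbon. Going by the values given here, no measured step involves a methyl entering in place of hydrogen, so nothing in the data bears directly on this change. Among the compounds with values here, the one step that exists, from compound 1 to compound 2, shows that a small change on this ring moved the number only within the scatter. On that basis, no step beyond the scatter is expected, so no change at the digits printed from compound 3 to compound 4 (within the scatter) is the estimated outcome. Compound 4 is therefore expected to give about 52%, with a likely range from 38% to 66%.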

Compound 4, a percentage reported as inhibition, in the whole organism at one dose (the size of the read-out at that dose, not a potency): 49%
The estimate for compound 4 lay 3 percentage points above the measured number; the range from low to high includes it.
By their numbers in this assay, from the lowest: compounds 4, 3, 2 and 1 (each within the scatter of the next, the first and the last beyond it).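

Methyl in place of hydrogen gives a number 3 percentage points lower from compound 3 to compound 4 (within the scatter) in this assay at this aromatic carbon, which is ortho to a methoxy group and two atoms from the ring nitrogen. For the compounds shown here, this is the first step here in which a methyl enters in place of hydrogen, and it shows that this position accepts that one added carbon with no difference that can be told from the scatter at this single oral dose and time. No measurement shown explains this result or says what the added methyl does inside the animal.

On these data alone, whether a different group on this carbon, such as an ethyl chain, an amine or a carboxylic acid, would move the number beyond the scatter remains open. Also open, as far as these compounds go, are how the same methyl would read on the larger core of compound 2, and whether a series of doses would separate compound 3 and compound 4 where one dose does not.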